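The source may hold more compounds than are shown below. What is called first, only, known or untested is meant among the compounds shown, and "the series" means these compounds.

Measured so far in a functional assay on MDA-MB-231 cells (Homo sapiens) for cytotoxicity, read by MTT assay, with a stated time of 48 h; a lower number here means a stronger inhibitor, a higher number a weaker inhibitor:
- compound 1, `COC(=O)Cn1cc(CO[C@H]2CC(=O)[C@@H]3OC[C@H]2O3)nn1`, gives 21300 nM
- compound 2, `C=C(C)Cn1cc(CO[C@H]2CC(=O)[C@@H]3OC[C@H]2O3)nn1`, gives 26700 nM

Compound 2 stands where compound 1 stands: the two numbers cannot be told apart, since the step of a 1.3-fold higher number from compound 1 to compound 2 (0.10 log units; within the scatter) lies within the scatter. Both compounds sit at the weak end of this assay, and nothing in the pair separates one from the other.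

Compound 3, `O=C1C[C@H](OCc2cn(-c3ccccc3Cl)nn2)[C@H]2CO[C@@H]1O2`, is not yet measured. It differs from compound 2 in one place: 2-chlorophenyl in place of 2-methylprop-2-en-1-yl on an aromatic nitrogen. For the measured compounds named here, the only measured step, from compound 1 to compound 2, changes a group on the saturated chain carbon bound to the aromatic nitrogen, not on the aromatic nitrogen itself, so it bears on the new change only loosely. That step was small, and no change at the aromatic nitrogen of the shared core has been measured. In this assay, compound 3 is therefore expected to give a number close to that of compound 2, with the step of a 1.1-fold lower number from compound 2 to compound 3 (0.05 log units; within the scatter) estimated as lying within the scatter, in no firm direction. Compound 3 is estimated at 24000 nM, with a range from 7000 nM to 70000 nM.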

Compound 3, half-maximal inhibitory concentration: 26400 nM
For compound 3 the middle estimate is 1.1-fold (0.04 log units) below the measured one; measured number inside the range.
By their numbers in this assay, from the lowest: compounds 1, 3 and 2 (each within the scatter of the next).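

In this assay, for the compounds shown here, the aromatic nitrogen carries a six-membered aromatic ring for the first time, and the change to 2-chlorophenyl leaves the number where it was, both against 2-methylprop-2-en-1-yl (a 1.0-fold lower number from compound 2 to compound 3 (0.00 log units; within the scatter)) and against (methoxycarbonyl)methyl (a 1.2-fold higher number from compound 1 to compound 3 (0.09 log units; within the scatter)). The earlier pair compared only two open chains, whereas this result shows that a group of 7 heavy atoms with a ring can take the place of a chain of 4 heavy atoms without any step beyond the scatter, so the three groups on this nitrogen cannot be told apart here. Nothing available explains why these changes leave the number unmoved.

Going by these compounds, whether an amine, a carboxylic acid or a longer chain on the aromatic nitrogen would move the number beyond the scatter stays open, as does the part played by the chlorine, for which plain phenyl would be the direct comparison. Changes elsewhere on the shared core, such as a hydroxyl in place of the carbonyl, are equally open.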